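A 3-methylphenyl swap and rat microsomal half-life

The source may report more compounds than this note shows. Statements on the series, on what has been measured and on what is new or still open speak of the compounds shown alone.

- Compound 1 `Cc1oc(-c2ccccc2Cl)nc1CN1CCC(C(=O)NCCCN2C[C@H](C)C[C@H](C)C2)CC1`: 0.25 h
- Compound 2 `Cc1oc(-c2ccc(Cl)cc2)nc1CN1CCC(C(=O)NCCCN2C[C@H](C)C[C@H](C)C2)CC1`: > 0.5 h
- Compound 3 `Cc1oc(-c2c(F)cccc2F)nc1CN1CCC(C(=O)NCCCN2C[C@H](C)C[C@H](C)C2)CC1`: 0.35 h

In an ADME assay on microsomes from liver (Rattus norvegicus) for metabolic stability, read by LC-MS, using NADPH, at 37 degrees C (a higher number here means that the compound lasts longer, a lower number that the compound disappears faster), compound 3 gives 0.35 h, within the scatter of compound 1, which gives 0.25 h. Compound 2 gives > 0.5 h, and this is a limit of the assay, not a number.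

Compound 4 `Cc1cccc(-c2nc(CN3CCC(C(=O)NCCCN4C[C@H](C)C[C@H](C)C4)CC3)c(C)o2)c1` carries 3-methylphenyl in place of 2,6-difluorophenyl on an aromatic carbon of the shared core: 3-methylphenyl in place of 2,6-difluorophenyl on an aromatic carbon. Three measured changes at this same place bear on it: a 1.4-fold higher number from compound 1 to compound 3 (0.15 log units; within the scatter), an at least 2.0-fold higher number from compound 1 to compound 2 (0.30 log units; that floor lies within the scatter) and an at least 1.4-fold lower number from compound 2 to compound 3 (0.15 log units; that floor lies within the scatter). For the measured compounds named here, all three lie within the scatter, although two of them rest on a limit, and no measured compound carries 3-methylphenyl. No step beyond the scatter is therefore expected in this assay. The expected step is no change at the digits printed from compound 3 to compound 4 (within the scatter). Compound 4 is estimated at 0.35 h, with an expected range of 0.18 h to 0.7 h.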

Compound 4, half-life: > 0.5 h
Compound 4: a limit, no number; the forecaster's own chance of this, stated with the estimate: 20%; at least 1.4-fold (0.15 log units) between middle value and limit.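

In this assay compound 4 gives > 0.5 h, which is a limit of the assay and not a number. The swap to 3-methylphenyl gives an at least 1.4-fold higher number from compound 3 to compound 4 (0.15 log units; that floor lies within the scatter) and an at least 2.0-fold higher number from compound 1 to compound 4 (0.30 log units; that floor lies within the scatter), so a phenyl ring with no chlorine or fluorine also reaches the limit at this place, although neither floor lies beyond the scatter. The step between compound 2 and compound 4 cannot be read, and the two compounds cannot be ordered, for both rest on the same limit: the limit of > 0.5 h in this assay, at which 2 of the 4 values shown sit.

From the compounds shown here alone, how far compound 2 and compound 4 lie past that limit stays open. So does whether an amine or a methoxy group on the phenyl ring would keep a compound at the limit in this assay.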